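The source may hold more compounds than are shown below. What is called first, only, known or untested is meant among the compounds shown, and "the series" means these compounds.

In an ADME assay on Vero cells (Chlorocebus sabaeus) for inhibition (a higher number here means that more compound is tolerated, a lower number that less compound is tolerated), compound 3 (`COc1cccc(/C=C2\CCC/C(=C\c3ccccc3)C2=O)c1OC`) reads 33500 nM and stands level with compound 1 (`O=C1/C(=C/c2ccc(Cl)cc2)CCC/C1=C\c1ccc(Cl)cc1`), which reads 32100 nM within the usual scatter. Compound 2 (`COc1ccc(/C=C2\CCC/C(=C\c3ccc([N+](=O)[O-])cc3)C2=O)cc1`) reads 435000 nM and lies beyond the scatter from compound 3 on the tolerated side.

Compound 4 (`COc1cccc(/C=C2\CCC/C(=C\c3ccc([N+](=O)[O-])cc3)C2=O)c1OC`) departs from compound 3 in one place, nitro in place of hydrogen on an aromatic carbon, para to a large group (nitro in place of hydrogen on an aromatic carbon), which amounts to phenyl to 4-nitrophenyl. Among the compounds with values here, no two measured compounds differ in only one place, so this change has not been seen on its own. Within the data shown here, the sole measured compound with a 4-nitrophenyl group is compound 2 at 435000 nM and it differs from compound 4 elsewhere as well. An upward move beyond the scatter is therefore expected, but smaller than the whole gap between compound 3 and compound 2, since part of that gap may belong to the other difference. The expected move is a 3.6-fold higher number from compound 3 to compound 4 (0.55 log units; beyond the scatter) and this estimate rests on a single comparison. For compound 4 the estimated value is 120000 nM with an expected range from 40000 nM to 350000 nM in this assay.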

Compound 4, half-maximal cytotoxic concentration: < 10000 nM
Compound 4: only a limit was reported; the forecaster's own chance of this, stated with the estimate: 10%; middle value at least 12-fold (1.07 log units) away from the limit.
By their numbers in this assay, from the lowest: compounds 1 and 3 (each within the scatter of the next); then compound 2. At a limit, below all of these: compound 4.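

Nitro in place of hydrogen on an aromatic carbon, para to a large group, can now be read on its own for the first time, which no earlier pair allowed: in this assay phenyl to 4-nitrophenyl gives an at least 3.3-fold lower number from compound 3 to compound 4 (0.52 log units; beyond the scatter), so less compound is tolerated with the 4-nitrophenyl group on this core. Compound 4 reads < 10000 nM, which is a limit and not a number: the limit of < 10000 nM in this assay, at which 1 of the 4 values shown sits. The direction of the step beyond the scatter is thus settled for this one pair, while its size has only a lower end, and the position is shown to be one where a single added group can shift this read-out.

Within the data shown here, whether the same change moves the number the same way on the core of compound 1 or of compound 2 stays open, since this is the only pair that carries it. Also open, on these data alone, is whether an amine or a carboxylic acid in place of the nitro, on the same aromatic carbon, would give a step of the same direction, and the values shown give no cause for the step.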